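Sulfur substituent exchange: compound 2 to compound 3

This account rests on a few compounds, and the source may have more. Where it says the series, first, only, none or still open, it means among the compounds named here.

Measured so far:
compound 1 `O=C(CCCN1CCC(n2cnc3ccccc32)CC1)c1ccc(F)cc1` — in a functional assay on the whole organism (strain STD-ddY) with Mus musculus as the target, with stated times of 1 h and 24 h (on this read-out lower numbers stand for an effect already at smaller amounts and higher numbers for an effect only at larger amounts of compound), compound 1 gives > 3 mg/kg, a limit of the assay
compound 2 `O=C(CCCN1CCC(n2c(SCc3ccccc3)nc3ccccc32)CC1)c1ccc(F)cc1` — in this assay compound 2 gives 0.76 mg/kg

For the measured compounds named here, compound 2 holds the only number in this assay; the other value is a limit (the limit of > 3 mg/kg in this assay, at which 1 of the 2 values shown sits). Going by the values given here, the one step with a measurement is an at least 3.9-fold lower number from compound 1 to compound 2 (0.59 log units; beyond the scatter).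

Compound 3 `CCOC(=O)Sc1nc2ccccc2n1C1CCN(CCCC(=O)c2ccc(F)cc2)CC1` keeps the sulfur and changes what it carries: ethoxycarbonyl in place of benzyl on a sulfur. The step from compound 1 to compound 2 bears on it only indirectly, since it shows the gain from installing benzylsulfanyl where compound 3 now has the same sulfur with ethoxycarbonyl on it. With benzyl gone, part of that gain is expected to be given back: the expected step is a 2.1-fold higher number from compound 2 to compound 3 (0.32 log units; beyond the scatter), upward but modest. For compound 3 the estimated value in this assay is 1.6 mg/kg, in the range 0.5 mg/kg to 5 mg/kg.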

Compound 3, dose for half-maximal effect: 0.65 mg/kg
Compound 3: middle estimate off by 2.5-fold (0.39 log units), on the high side, within the range that was stated.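

In this assay, benzyl on the sulfur is not required for the effect: ethoxycarbonyl takes its place with a 1.2-fold lower number from compound 2 to compound 3 (0.07 log units; within the scatter), so an aromatic ring at this position can give way to a group with no ring and with hydrogen-bond acceptors without a readable change. The gain over hydrogen on the aromatic carbon therefore appears with a second, quite different sulfur substituent, an at least 4.6-fold lower number from compound 1 to compound 3 (0.66 log units; beyond the scatter). Compound 1 gives only a limit of the assay, so the full size of that gain stays open: the limit of > 3 mg/kg in this assay, at which 1 of the 3 values shown sits.

Both substituted compounds carry sulfur, so the contribution of the sulfur itself cannot be separated from that of the group on it. An amine on the same aromatic carbon would bear on this, and a carboxylic acid or a longer alkyl chain on the sulfur would test how far the position accepts other groups.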